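Compound 4: a New Side Chain on the Shared Core

The compounds below may be only part of what the source reports. "The series", "measured", "known", "first", "only" and "open" are said of these compounds alone.

Measured in a functional assay on HT-29 cells (Homo sapiens) for cytotoxicity, read by MTT assay, with a stated time of 24 h, tested at 0.64 ug/mL; on this read-out lower numbers stand for a weaker effect and higher numbers for a stronger effect at the one concentration tested:
compound 1 `Cn1nnnc1SCC(=O)Nc1ccc(-c2nc(-c3ccccc3)c(-c3ccccc3)n2C)cc1` — 38%
compound 2 `Cc1nnc(SCC(=O)Nc2ccc(-c3nc(-c4ccccc4)c(-c4ccccc4)n3C)cc2)s1` — 34.8%
compound 3 `Cn1ccnc1SCC(=O)Nc1ccc(-c2nc(-c3ccccc3)c(-c3ccccc3)n2C)cc1` — 13.6%

Compound 2 gives the second highest of the three numbers in this assay: a number 3.2 percentage points lower from compound 1 to compound 2 (within the scatter) lies within the scatter, while a number 21.2 percentage points lower from compound 2 to compound 3 (beyond the scatter) lies beyond it. Compound 4 `CN(C)/C=C/N1CCN(CC(=O)Nc2ccc(-c3nc(-c4ccccc4)c(-c4ccccc4)n3C)cc2)CC1` differs from compound 2 by 4-(2-(dimethylamino)ethenyl)piperazin-1-yl in place of (5-methyl-1,3,4-thiadiazol-2-yl)sulfanyl on a saturated chain carbon bound to a carbonyl carbon. Within the data shown here, none of the measured steps makes this change; all three swap one five-membered aromatic ring for another on the sulfur. On these data alone, two of them, a number 24.4 percentage points lower from compound 1 to compound 3 (beyond the scatter) and a number 21.2 percentage points lower from compound 2 to compound 3 (beyond the scatter), show that a change at this place can shift the read-out beyond the scatter, so the direction stays open. Compound 4 is estimated at 25%, between 5% and 50%. The expected step is a number 9.8 percentage points lower from compound 2 to compound 4 (within the scatter).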

Compound 4, a percentage reported as activity, at one concentration (the size of the read-out at that concentration, not a potency): 3.1%
For compound 4 the middle estimate is 21.9 percentage points above the measured one; measured number below the stated range.
By their numbers in this assay, from the lowest: compound 4; then compound 3; then compounds 2 and 1 (each within the scatter of the next).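

In this assay the exchange for 4-(2-(dimethylamino)ethenyl)piperazin-1-yl on a saturated chain carbon bound to a carbonyl carbon gives a number 31.7 percentage points lower from compound 2 to compound 4 (beyond the scatter) and a number 34.9 percentage points lower from compound 1 to compound 4 (beyond the scatter) as well as a number 10.5 percentage points lower from compound 3 to compound 4 (beyond the scatter) and so places compound 4 beyond the scatter under all three sulfanyl compounds. The earlier compounds shown here varied only the aromatic ring on the sulfur, whereas this result shows that replacing the whole sulfanyl group also moves the read-out, and downward here.

The compounds shown do not separate the piperazine ring from its 2-(dimethylamino)ethenyl group, which a plain piperazin-1-yl or a morpholin-4-yl on that carbon would address. No available evidence accounts for this result.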